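A few compounds are considered here, and "the series" means these few. Any claim that something is new, unique, unknown or untested is made for them only; others in the source may bear on it.

Measured so far: compound 1 `O=C(CN(c1ncnc2c1ncn2C1CCCCO1)C1CC1)N[C@@H](CCC(=O)OCc1ccccc1)C(=O)OCc1ccccc1` gives 20.7%; compound 2 `O=C(CN(c1ncnc2c1ncn2C1CCCCO1)C1CC1)N[C@@H](CC(=O)OCc1ccccc1)C(=O)OCc1ccccc1` gives 7.82%; compound 3 `CC(C)(C)OC(=O)NCCCC[C@H](NC(=O)CN(c1ncnc2c1ncn2C1CCCCO1)C1CC1)C(=O)OCc1ccccc1` gives 28.4%.

In a functional assay on the whole organism (Tail, strain ICR) with Mus musculus as the target, in the tail flick test, with a stated time of 120 min, at a dose of 25 umol/kg by the oral route (a lower number here means a weaker effect, a higher number a stronger effect of the compound at the dose given), compound 3 stands highest of the three numbers, though its nearest neighbour, compound 1, lies only a number 7.7 percentage points higher from compound 1 to compound 3 (within the scatter), which is within the scatter, whereas the gap from compound 2 is larger: a number 20.6 percentage points higher from compound 2 to compound 3 (beyond the scatter). Compound 4 `CSCC[C@H](NC(=O)CN(c1ncnc2c1ncn2C1CCCCO1)C1CC1)C(=O)OCc1ccccc1` is not yet measured. It differs from compound 3 by methylsulfanyl in place of 2-((tert-butoxycarbonyl)amino)ethyl on a saturated chain carbon, three bonds along the chain from an amide-type nitrogen and a carbonyl carbon. Among the compounds with values here, the one measured step at the same place is that from compound 1 to compound 3, where 2-((tert-butoxycarbonyl)amino)ethyl replaced benzyloxycarbonyl with a change a number 7.7 percentage points higher from compound 1 to compound 3 (within the scatter), within the scatter. The other step, a number 12.9 percentage points lower from compound 1 to compound 2 (beyond the scatter), concerns a shorter chain at a different place and bears only loosely on the change here. Within the data shown here, no measured step exchanges a group for methylsulfanyl, so the expectation is uncertain, and an exchange at this place is expected to produce no step beyond the scatter, if anything a slight fall: a number 7.4 percentage points lower from compound 3 to compound 4 (within the scatter). Compound 4 is therefore estimated at 21%, with a range from 7% to 36% in this assay.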

Compound 4, a percentage reported as activity, at one dose (the size of the read-out at that dose, not a potency): 28.7%
Compound 4: the middle estimate sits 7.7 percentage points below what was measured; the range from low to high includes it.
By their numbers in this assay, from the lowest: compound 2; then compounds 1, 3 and 4 (each within the scatter of the next).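

In this assay, putting methylsulfanyl, with 2 heavy atoms, in place of 2-((tert-butoxycarbonyl)amino)ethyl, with 10 heavy atoms, gives a number 0.3 percentage points higher from compound 3 to compound 4 (within the scatter), so this place accepts the far smaller sulfur-bearing group without a measurable difference at this dose. The same holds against benzyloxycarbonyl at this place, with a number 8 percentage points higher from compound 1 to compound 4 (within the scatter), which leaves all three groups unseparated. Only compound 2 stands apart, with a number 20.9 percentage points higher from compound 2 to compound 4 (beyond the scatter), where (methylsulfanyl)methyl replaces benzyloxycarbonyl two bonds along the chain from an amide-type nitrogen and a carbonyl carbon.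

No evidence at hand accounts for these numbers. Open, as far as these compounds go, is how a free amine, a carboxylic acid or a longer chain ending in methylsulfanyl would read at this place.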